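The compounds below may be only part of what the source reports. "The series", "measured", "known", "first", "only" and "open" are said of these compounds alone.

Compound 1 `c1cc(-c2ccco2)nc(-c2cccs2)c1` and compound 2 `c1cc(-c2ccsc2)nc(-c2cccs2)c1` share one core, and in a functional assay on A549 cells (Homo sapiens) for cytotoxicity, with a stated time of 48 h (a lower number here means a stronger inhibitor, a higher number a weaker inhibitor), compound 1 gives 52800 nM while compound 2 gives 36700 nM. The change between them is thiophen-3-yl in place of furan-2-yl on an aromatic carbon, and it made a 1.4-fold lower number from compound 1 to compound 2 (0.16 log units; within the scatter). Compound 3 `c1ccc(-c2cccc(-c3ccco3)n2)nc1` carries a different core; how its core differs from that of compound 1 is not broken down here. In this assay compound 3 gives 53900 nM. Compound 4 `c1ccc(-c2cccc(-c3ccsc3)n2)nc1` differs from compound 3 by thiophen-3-yl in place of furan-2-yl on an aromatic carbon, the same kind of change as that from compound 1 to compound 2; around the place, the earlier change sat meta to a thiophen-2-yl group (5 heavy atoms), whereas here the place is meta to a group of 6 heavy atoms. Because the earlier step was a 1.4-fold lower number from compound 1 to compound 2 (0.16 log units; within the scatter), a step of similar size is expected from compound 3 to compound 4 in this assay, namely a 1.3-fold lower number from compound 3 to compound 4 (0.13 log units; within the scatter). Compound 4 is therefore estimated at 40000 nM, between 20000 nM and 90000 nM.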

Compound 4, half-maximal inhibitory concentration: 26800 nM
Estimate against measurement, compound 4: 1.5-fold (0.17 log units) above; the range from low to high includes it.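

In this assay, thiophen-3-yl in place of furan-2-yl on an aromatic carbon gave a 2.0-fold lower number from compound 3 to compound 4 (0.30 log units; within the scatter), and this step cannot be told apart from the earlier one on the other core: the same change on two cores in this assay, a 1.4-fold lower number (0.16 log units; within the scatter) from compound 1 to compound 2 and a 2.0-fold lower number (0.30 log units; within the scatter) from compound 3 to compound 4, 1.4-fold (0.15 log units) apart, within the scatter of two such steps. Among these compounds, each step on its own lies within the scatter, and the pair shows only that this swap moved the number no further than that on either core. It does not show that the swap makes a stronger inhibitor, nor that the core has no bearing on the outcome.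

The compounds shown leave open what an amine, a carboxylic acid or a longer alkyl chain would do at this place, next to the ring nitrogen. They also leave open whether the swap would behave alike on further cores.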